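The compounds below may be only part of what the source reports. "The series", "measured", "known", "first", "only" and "open" are said of these compounds alone.

Working notes on the series. Compound 1 `CC(=O)Oc1ccccc1C(=O)O[C@H]1CO[C@H]2[C@@H]1OC[C@H]2OC(C)=O` in an ADME assay on a cell-free system (plasma, Homo sapiens) for metabolic stability, with Plasma (Rattus norvegicus) as the target, read by HPLC, at pH 7.4 (a higher number here means that the compound lasts longer, a lower number that the compound disappears faster), gives 0.0608 h, the second highest of the three numbers measured. Its nearest neighbour is compound 3 `CC(=O)Oc1ccccc1C(=O)O[C@H]1CO[C@H]2[C@@H]1OC[C@H]2OC(=O)c1cnccc1Cl`, which gives 0.0642 h; the two sit within the scatter of each other, as shown by a 1.1-fold higher number from compound 1 to compound 3 (0.02 log units; within the scatter). Compound 2 `CCCCC(=O)O[C@@H]1CO[C@H]2[C@@H]1OC[C@@H]2OC(=O)c1ccccc1OC(C)=O` gives 0.0198 h, and the gap is beyond the scatter: a 3.1-fold lower number from compound 1 to compound 2 (0.49 log units; beyond the scatter), with the reverse comparison a 3.2-fold higher number from compound 2 to compound 3 (0.51 log units; beyond the scatter).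

Compound 4 `CC(=O)Oc1ccccc1C(=O)O[C@H]1CO[C@H]2[C@@H]1OC[C@H]2O[N+](=O)[O-]` differs from compound 1 at the other side of the core: nitro in place of acetyl on an oxygen on a saturated carbon. Cut one bond further out the difference reads acetoxy to nitrooxy. Among the measured compounds shown here, no measured step alters this oxygen on a saturated carbon whose other neighbours are a saturated ring carbon; the steps on file concern the carbonyl carbon of the other ester. The closest guide is compound 1 to compound 3, where a larger group on a carbonyl carbon left this assay within the scatter, whereas the propyl step moved it modestly. For the measured compounds named here, the nitro group has no acyl counterpart among the measured compounds, so the direction is open; no step beyond the scatter is expected. Compound 4 is estimated at 0.07 h, range 0.025 h to 0.2 h, meaning an expected step of a 1.2-fold higher number from compound 1 to compound 4 (0.06 log units; within the scatter).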

Compound 4, half-life: 0.0144 h
Beside the measured number, compound 4's estimate is 4.9-fold (0.69 log units) above it; the whole stated range lies above it.
By their numbers in this assay, from the lowest: compounds 4 and 2 (each within the scatter of the next); then compounds 1 and 3 (each within the scatter of the next).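

In this assay the oxygen on a saturated carbon proves to be a place where the number can move: nitro in place of acetyl gives a 4.2-fold lower number from compound 1 to compound 4 (0.63 log units; beyond the scatter) and nitro in place of (4-chloropyridin-3-yl)carbonyl gives a 4.5-fold lower number from compound 3 to compound 4 (0.65 log units; beyond the scatter) while the earlier exchange of methyl for 4-chloropyridin-3-yl on the carbonyl carbon stayed within the scatter. Nitro in place of butylcarbonyl gives a 1.4-fold lower number from compound 2 to compound 4 (0.14 log units; within the scatter) so the size of this change depends on the group it replaces, and compound 4 sits within the scatter of compound 2, not with compounds 1 and 3. Nothing on file bears on the reason for these steps.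

On these data alone, whether the lower numbers belong to nitro itself or to the loss of the acyl group stays open. A methyl ether, an amine or a carbamate on this oxygen would separate the two.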